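A few compounds are considered here, and "the series" means these few. Any claim that something is new, unique, unknown or untested is made for them only; others in the source may bear on it.

Three compounds of the shared core have been run in a functional assay on HeLa cells (Homo sapiens) for inhibition, read by CCK-8 assay, with a stated time of 48 h; on this read-out lower numbers stand for stronger inhibition and higher numbers for weaker inhibition. Compound 1 `Cn1ccc2cc(-c3cc4nccc(-c5ccc(F)cc5)n4n3)ccc21` gives 5210 nM in this assay. Compound 2 `COc1cc(-c2ccnc3cc(-c4ccc(C(C)(C)C)cc4)nn23)cc(OC)c1OC` reaches only a limit of this assay, > 10000 nM. Compound 3 `Cc1ccc(-c2cc3nccc(-c4ccc(F)cc4)n3n2)cc1` likewise reaches only a limit, > 10000 nM. Compound 2 therefore sits at the limit of > 10000 nM in this assay, at which 2 of the 3 values shown sit, with no number of its own to anchor a comparison. Among the compounds with values here, no step between two measured compounds that differ in one place is available, so the move to compound 4 `COc1cc(-c2ccnc3cc(-c4cccc(C#N)c4)nn23)cc(OC)c1OC` rests on the structures alone. Compound 4 differs from compound 2 by 3-cyanophenyl in place of 4-(tert-butyl)phenyl on an aromatic carbon. Because compound 2 gave only the limit > 10000 nM, any step can be judged only in one direction, and a step no larger than the scatter remains the plainest expectation. The expected step from compound 2 to compound 4 is an at least 1.2-fold lower number from compound 2 to compound 4 (0.09 log units; that floor lies within the scatter), a small move toward stronger inhibition with wide uncertainty. Compound 4 is estimated at 8000 nM, with a range of 2500 nM to 20000 nM.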

Compound 4, half-maximal inhibitory concentration: > 10000 nM
Compound 4: no number, only a limit; the forecaster's own chance of this, stated with the estimate: 45%; at least 1.2-fold (0.09 log units) between middle value and limit.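

Compound 2 and compound 4 both give only a limit in this assay, and the step between them cannot be read. The compounds shown leave open whether 3-cyanophenyl in place of 4-(tert-butyl)phenyl on an aromatic carbon changes inhibition at all.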